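Swapping hydroxy for methylamino on compound 2

A few compounds are considered here, and "the series" means these few. Any claim that something is new, unique, unknown or untested is made for them only; others in the source may bear on it.

Measured in a functional assay on MCF7 cells (Homo sapiens) for antiproliferative activity, read by MTT assay, with a stated time of 48 h; a lower number here means a stronger inhibitor, a higher number a weaker inhibitor:
Compound 1 `COc1ccc(C(=O)c2ccc(OC)c3c2OC(C)(C)C=C3)c(NC(=O)CBr)c1`: 2360 nM
Compound 2 `COc1ccc(C(=O)c2ccc(OC)c3c2C=CC(C)(C)O3)c(NC(=O)CO)c1`: 940 nM

Of these two results, compound 2 holds the lower number, at 940 nM, so it is the stronger inhibitor of the pair. Its gap to compound 1 lies beyond the usual scatter of repeated measurements.

The next compound to be tested is compound 3 `CNCC(=O)Nc1cc(OC)ccc1C(=O)c1ccc(OC)c2c1C=CC(C)(C)O2`. It keeps the core of compound 2 and changes one group: methylamino in place of hydroxy on a saturated chain carbon bound to a carbonyl carbon. Read one bond further out, hydroxymethyl becomes (methylamino)methyl.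

Within the data shown here, no measured pair of compounds shows what this swap does, so the data give no firm direction in this assay. The expectation is therefore no step beyond the scatter, with a slight lean towards a weaker result. The estimated change is a 1.3-fold higher number from compound 2 to compound 3 (0.11 log units; within the scatter). For compound 3 the estimated value is 1200 nM, with an expected range of 400 nM to 3500 nM. Among the measured compounds shown here, the range is wide, as only two measured compounds support it.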

Compound 3, half-maximal inhibitory concentration: 3040 nM
For compound 3 the middle estimate is 2.5-fold (0.40 log units) below the measured one; measured number inside the range.
By their numbers in this assay, from the lowest: compound 2; then compounds 1 and 3 (each within the scatter of the next).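

In this assay, the group on this saturated chain carbon bound to a carbonyl carbon clearly matters: replacing hydroxy with methylamino gives a 3.2-fold higher number from compound 2 to compound 3 (0.51 log units; beyond the scatter) and so a weaker inhibitor. Among these compounds, this is the first measured pair that differs in one place, so the earlier compounds alone could not show whether a change here would have any effect on the result. The loss appears even though hydroxy and methylamino each count 1 hydrogen-bond donor and 1 hydrogen-bond acceptor and neither carries a net charge, so those counts alone do not settle the outcome in this pair.

No measurement shown here gives a reason for this loss.

This single step also leaves open how other groups at the same place would compare, such as dimethylamino, a carboxylic acid or a longer chain ending in hydroxy, and whether any of them would match or improve on hydroxy.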